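The compounds below may be only part of what the source reports. "The series", "measured", "known", "first", "only" and "open" are said of these compounds alone.

Measured so far:
- compound 1 `COc1ccc(/C=C/C(=O)c2ccc(N3CCNCC3)cc2)c(OC)c1`: 21500 nM
- compound 2 `CCN1CCC(c2cc(C(=O)/C=C/c3ccccc3)c(OC)cc2OC)CC1`: 6100 nM

In a functional assay on MCF7 cells (Homo sapiens) for antiproliferative activity, read by MTT assay, with a stated time of 72 h (a lower number here means a stronger inhibitor, a higher number a weaker inhibitor), compound 2 gives 6100 nM, the lower of the two numbers, and the gap up to compound 1 lies beyond the scatter. Compound 3 `CCN1CCC(c2cc(C(=O)/C=C/c3ccccc3Cl)c(OC)cc2OC)CC1` differs from compound 2 in one place: chloro in place of hydrogen on an aromatic carbon. This is chloro in place of hydrogen on an aromatic carbon, turning phenyl into 2-chlorophenyl. Among the compounds with values here, no measured pair shows this change, so only a small step in this assay is expected, slightly downward and perhaps within the scatter. The estimated change is a 1.2-fold lower number from compound 2 to compound 3 (0.09 log units; within the scatter). For compound 3 the expected value is 5000 nM, with an estimated range from 1800 nM to 14000 nM.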

Compound 3, half-maximal inhibitory concentration: 3600 nM
Compound 3: middle estimate off by 1.4-fold (0.14 log units), on the high side; the range from low to high includes it.
By their numbers in this assay, from the lowest: compounds 3 and 2 (each within the scatter of the next); then compound 1.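

In this assay, chloro in place of hydrogen on the aromatic carbon ortho to a large group, turning phenyl into 2-chlorophenyl, gives a 1.7-fold lower number from compound 2 to compound 3 (0.23 log units; within the scatter). This single pair therefore shows that the position can carry a chlorine without a change that stands clear of the scatter. Nothing available explains this result.

From the compounds shown here alone, it remains open whether a different group at this position, such as fluoro or an amine, would give a step beyond the scatter. Going by these compounds, whether chloro on another carbon of that ring would behave the same way is also open.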